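Only Limits So Far: From Indolyl to Methylsulfonylphenyl

A few compounds are considered here, and "the series" means these few. Any claim that something is new, unique, unknown or untested is made for them only; others in the source may bear on it.

Three compounds have been measured in an ADME assay on Raji cells (Homo sapiens) for cytotoxicity, read by CellTiter-Glo and resazurin assay, with a stated time of 72 h (on this read-out higher numbers stand for an effect only at larger amounts of compound and lower numbers for an effect already at smaller amounts), and each of the three values is a limit of that assay rather than a number:

Compound 1 `CCOC(=O)CCCCCOc1cccc(CN(C(=O)c2ccc(-c3cccc(-c4ccccc4)c3)cc2)C(C)C)c1`: > 26000 nM
Compound 2 `CCOC(=O)CCCCCOc1cccc(CN(C(=O)c2ccc(-c3cccc(Oc4ccccc4)c3)cc2)C(C)C)c1`: > 19600 nM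
Compound 3 `CCOC(=O)CCCCCOc1cccc(CN(C(=O)c2ccc(-c3ccc4cc[nH]c4c3)cc2)C(C)C)c1`: > 26000 nM

Compound 3 therefore stands on a limit, as do compound 1 and compound 2, so none of the three can be placed above or below another. Compound 4 `CCOC(=O)CCCCCOc1cccc(CN(C(=O)c2ccc(-c3cccc(S(C)(=O)=O)c3)cc2)C(C)C)c1` arises from compound 3 by a single change: 3-(methylsulfonyl)phenyl in place of 1H-indol-6-yl on an aromatic carbon. Among the measured compounds shown here, two measured steps touch the same position. The step that the two limits leave unreadable from compound 1 to compound 2 and the step that the two limits leave unreadable from compound 1 to compound 3 both remain unreadable, since one value sits at the limit of > 19600 nM in this assay, at which 1 of the 3 values shown sits, and two sit at the limit of > 26000 nM in this assay, at which 2 of the 3 values shown sit. Nothing readable therefore points to any direction for the new change. The expectation is a step of a number no higher from compound 3 to compound 4 (the limit leaves the size open) that stays within the scatter, most probably ending again at a limit. Compound 4 is accordingly estimated at 26000 nM, with a range from 12000 nM to 60000 nM.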

Compound 4, half-maximal effective concentration: > 26000 nM
Compound 4 gave a limit, no number (the forecaster's own chance of this, stated with the estimate: 80%); the middle value sits exactly at the limit.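

In this assay compound 4 gives > 26000 nM, a limit and not a number. Among the compounds shown here, compound 1, compound 2 and compound 3 also stand on limits, and no step from any of them to compound 4 can be read. The compounds shown leave open at what concentration any of the four has an effect.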